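This account rests on a few compounds, and the source may have more. Where it says the series, first, only, none or still open, it means among the compounds named here.

Measured compounds:
compound 1 `N=C(N)N/N=C/c1ccc(/C=C/C(=O)c2cccc(Cl)c2)cc1` — 80.7%
compound 2 `N=C(N)N/N=C/c1ccc(/C=C/C(=O)c2ccc(Cl)cc2)cc1` — 56.4%
compound 3 `Cc1ccc(C(=O)/C=C/c2ccc(/C=N/NC(=N)N)cc2)c(C)c1` — 64.2%

In a functional assay on the whole organism (Ear) for inhibition, with Mus musculus as the target, with a stated time of 30 min, at a dose of 100 mg/kg by the intraperitoneal route (a lower number here means less inhibition, a higher number more inhibition at the dose given (going by the name of the read-out)), compound 3 gives 64.2%, the second highest of the three numbers. Its nearest neighbour is compound 2, and the step of a number 7.8 percentage points higher from compound 2 to compound 3 (within the scatter) lies within the scatter; the step of a number 16.5 percentage points lower from compound 1 to compound 3 (beyond the scatter) lies beyond it.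

Compound 4 `N=C(N)N/N=C/c1ccc(/C=C/C(=O)c2ccc(F)cc2)cc1` differs from compound 3 in one place: 4-fluorophenyl in place of 2,4-dimethylphenyl on a carbonyl carbon. All three measured steps concern the same place, the aryl group on the carbonyl carbon. The step of a number 24.3 percentage points lower from compound 1 to compound 2 (beyond the scatter) shows that a 4-chlorophenyl there sits well below the 3-chlorophenyl, and the step of a number 16.5 percentage points lower from compound 1 to compound 3 (beyond the scatter) shows the 2,4-dimethylphenyl also sits below it, while 4-chlorophenyl and 2,4-dimethylphenyl are within the scatter of each other. A 4-fluorophenyl is closest in kind to the 4-chlorophenyl of compound 2, so compound 4 is expected to land near compound 2, with a step of a number 9.2 percentage points lower from compound 3 to compound 4 (within the scatter) that is expected to stay within the scatter. Compound 4 is therefore estimated at 55%, in the range 40% to 70%.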

Compound 4, a percentage reported as inhibition, in the whole organism at one dose (the size of the read-out at that dose, not a potency): 90.7%
Beside the measured number, compound 4's estimate is 35.7 percentage points below it, and the stated range ends below it.
By their numbers in this assay, from the lowest: compounds 2 and 3 (each within the scatter of the next); then compounds 1 and 4 (each within the scatter of the next).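

In this assay, for the compounds shown here, the step of a number 34.3 percentage points higher from compound 2 to compound 4 (beyond the scatter) shows that, with the ring position unchanged, the identity of the halogen on the aryl group at the carbonyl carbon matters; the earlier compounds compared only two positions of chloro. The step of a number 26.5 percentage points higher from compound 3 to compound 4 (beyond the scatter) sets 4-fluorophenyl clearly apart from 2,4-dimethylphenyl, while the step of a number 10 percentage points higher from compound 1 to compound 4 (within the scatter) does not separate it from 3-chlorophenyl, so the low reading of compound 2 cannot be taken as a general feature of a halogen at that ring position. Nothing available accounts for the gap between the fluoro and chloro compounds.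

Still open, as far as these compounds go, is how a bromophenyl, a methoxyphenyl or an aminophenyl group on the carbonyl carbon would read in this assay. From the compounds shown here alone, each number comes from a single dose, so the potency order of the compounds also remains open.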